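The source may hold more compounds than are shown below. What is called first, only, known or untested is meant among the compounds shown, and "the series" means these compounds.

Measured so far in a functional assay on A549 cells (Homo sapiens) for inhibition; on this read-out higher numbers stand for weaker inhibition and lower numbers for stronger inhibition:
- compound 1 `COc1cc(/C=C\c2ccc3c(ccn3S(=O)(=O)c3ccccc3)c2)cc(OC)c1OC`: > 5000 nM
- compound 2 `COc1cc(/C=C/c2ccc3c(ccn3C)c2)cc(OC)c1OC`: 470 nM

Going by the values given here, compound 2 gives 470 nM, the only actual number so far. Compound 1 reads > 5000 nM, which is a limit of the assay and not a number.

The next comparison is with compound 3 `COc1cc(/C=C\c2ccc3c(ccn3C)c2)cc(OC)c1OC`, which keeps the atoms and bonds of compound 2: the two compounds have the same atoms and bonds and differ only in configuration as drawn: 1 of 1 stereo elements differ; a double bond is drawn E in compound 2 and Z in compound 3. Among the compounds with values here, no measured pair shows this change on its own, so its size cannot be read from the data and remains a judgement. Stronger inhibition in this assay, by a margin beyond the usual scatter, is expected, with an estimated 9.4-fold lower number from compound 2 to compound 3 (0.97 log units; beyond the scatter). Compound 3 is estimated at 50 nM, with an expected range of 8 nM to 400 nM.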

Compound 3, half-maximal inhibitory concentration: 470 nM
Beside the measured number, compound 3's estimate is 9.4-fold (0.97 log units) below it; the whole stated range lies below it.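

In this assay the double bond can now be read on its own, and the step shows no change at the digits printed from compound 2 to compound 3 (within the scatter), with nothing else altered in the pair: the fact that compounds 2 and 3 differ only in the configuration as drawn. Compound 1 reads > 5000 nM, which is a limit of the assay and not a number. Going by these compounds alone, with the double bond drawn Z in both compounds, methyl in place of phenylsulfonyl on the aromatic nitrogen gives an at least 10-fold lower number from compound 1 to compound 3 (1.02 log units; beyond the scatter), so the first comparison at this nitrogen is a large one.

Within the data shown here, whether the double bond configuration stays without effect with another group on that nitrogen remains open, as the only pair showing it carries methyl. Going by these compounds, how ethyl, benzyl or acetyl on the aromatic nitrogen would read against methyl and phenylsulfonyl also remains open.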